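The compounds below may be only part of what the source reports. "The series", "measured", "known", "first", "only" and "open" are said of these compounds alone.

In an ADME assay on HEK293 cells (Homo sapiens) for cytotoxicity, read by MTT assay, with a stated time of 48 h (a higher number here means a weaker inhibitor, a lower number a stronger inhibitor), compound 1 (`O=C1/C(=C\c2ccccc2)S/C(=N/c2ccccc2)N1Cc1ccncc1`) gives 64700 nM alongside compound 2 (`COc1ccc(/C=C2/S/C(=N/c3ccccc3)N(Cc3ccncc3)C2=O)cc1`) at 47900 nM and compound 3 (`O=C1/C(=C\c2ccc(Cl)cc2)S/C(=N/c2ccccc2)N1Cc1ccncc1`) at 42300 nM in this small set, so compound 1 stands level with both within the scatter. Compound 4 (`CN(C)c1ccc(/C=C2/S/C(=N/c3ccccc3)N(Cc3ccncc3)C2=O)cc1`) has not yet been measured. It differs from compound 1 by dimethylamino in place of hydrogen on an aromatic carbon, para to a large group. Two measured changes are of the same kind: methoxy in place of hydrogen on an aromatic carbon (a 1.4-fold lower number from compound 1 to compound 2 (0.13 log units; within the scatter)) and chloro in place of hydrogen on an aromatic carbon (a 1.5-fold lower number from compound 1 to compound 3 (0.18 log units; within the scatter)). Both stay within the scatter, as does the exchange of methoxy for chloro (a 1.1-fold lower number from compound 2 to compound 3 (0.05 log units; within the scatter)). These steps give no reason to expect a change beyond the scatter in this assay when dimethylamino enters. The expected step (a 1.4-fold lower number from compound 1 to compound 4 (0.16 log units; within the scatter)) therefore stays within the scatter. For compound 4 the estimated value is 45000 nM with an expected range from 20000 nM to 90000 nM in this measurement.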

Compound 4, half-maximal inhibitory concentration: 122000 nM
Compound 4: the middle estimate sits 2.7-fold (0.43 log units) below what was measured, and the stated range ends below it.
By their numbers in this assay, from the lowest: compounds 3, 2, 1 and 4 (each within the scatter of the next, the first and the last beyond it).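

For the compounds shown here, at this place, para to a large group, dimethylamino is the first substituent to stand apart from another. Against hydrogen it stays within the scatter (a 1.9-fold higher number from compound 1 to compound 4 (0.28 log units; within the scatter)), yet in this assay it separates from both chloro (a 2.9-fold higher number from compound 3 to compound 4 (0.46 log units; beyond the scatter)) and methoxy (a 2.5-fold higher number from compound 2 to compound 4 (0.41 log units; beyond the scatter)), whereas the earlier exchange of methoxy for chloro did not. Substituents at this place can therefore differ from each other while none differs from hydrogen, and no measurement offered here accounts for this.

The compounds shown leave open whether the gap follows the amine itself, which a primary amine, methylamino or morpholine at the same place would test. They also leave open how a carboxylic acid there would compare, and whether dimethylamino gives the same result elsewhere on the ring.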